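Swapping the dichlorophenyl thioether for a fluorophenyl

The source may hold more compounds than are shown below. What is called first, only, known or untested is meant among the compounds shown, and "the series" means these compounds.

Compound 1 `Nc1cc(N)c2nc(-c3ccccc3)c(Oc3ccc(Cl)c(Cl)c3)nc2c1` carries a 3,4-dichlorophenoxy group on the shared core. In a functional assay on OVCAR-4 cells (Homo sapiens) for inhibition, read by sulforhodamine B assay, with a stated time of 48 h (on this read-out lower numbers stand for stronger inhibition of growth and higher numbers for weaker inhibition of growth), compound 1 gives < 100000 nM, which is a limit of the assay rather than a number. Compound 2 `Nc1cc(N)c2nc(-c3ccccc3)c(Sc3ccc(Cl)c(Cl)c3)nc2c1` carries the (3,4-dichlorophenyl)sulfanyl group in place of the 3,4-dichlorophenoxy group. In this assay compound 2 gives < 100000 nM, again a limit of the assay and not a number. For the measured compounds named here, the step that the two limits leave unreadable from compound 1 to compound 2 therefore cannot be sized, and for compound 2 the only information is this limit; the evidence behind it is the limit of < 100000 nM in this assay, at which 2 of the 2 values shown sit.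

Compound 3 `Nc1cc(N)c2nc(-c3ccccc3)c(Sc3ccc(F)cc3)nc2c1` differs from compound 2 by the change (4-fluorophenyl in place of 3,4-dichlorophenyl on a sulfur). Going by the values given here, no measured step bears on this change in a readable way, so the size and direction of the step in this assay cannot be drawn from the data. Compound 3 is therefore expected to sit somewhere within the range that its limit-bounded neighbour allows, with the step that the limit leaves unreadable from compound 2 to compound 3 as the working guess. The estimate for compound 3 is 20000 nM, with a range from 3000 nM to 100000 nM.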

Compound 3, concentration for total growth inhibition: 56200 nM
The estimate for compound 3 lay 2.8-fold (0.45 log units) below the measured number, within the range that was stated.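

The steps from compound 1 and from compound 2 to compound 3 cannot be read in this assay: compound 2 stands only as a limit of the assay, < 100000 nM, and compound 1 does likewise. The compounds shown leave open how far growth inhibition differs between 3,4-dichlorophenyl and 4-fluorophenyl on a sulfur, or between 3,4-dichlorophenoxy and (3,4-dichlorophenyl)sulfanyl.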